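The source may report more compounds than this note shows. Statements on the series, on what has been measured and on what is new or still open speak of the compounds shown alone.

Compounds 1 to 4 share one core and differ only in the aromatic group on a saturated chain carbon bound to a nitrogen on an aromatic ring. They belong to a series examined in a functional assay on HOS cells (Homo sapiens) for antiproliferative activity, with a stated time of 72 h; on this read-out lower numbers stand for stronger inhibition and higher numbers for weaker inhibition. Compound 1 `OC[C@H]1O[C@@H](n2cnc3c(NCc4ccc(F)cc4F)ncnc32)[C@H](O)[C@@H]1O` gives > 166000 nM, which is a limit of the assay and not a number. Compound 2 `OC[C@H]1O[C@@H](n2cnc3c(NCc4c(F)ccc(F)c4F)ncnc32)[C@H](O)[C@@H]1O` has no usable result: "not determined" (no result reported). Compound 3 `OC[C@H]1O[C@@H](n2cnc3c(NCc4cccc(O)c4O)ncnc32)[C@H](O)[C@@H]1O` gives > 166000 nM, again only a limit. The series therefore stands at the limit of > 166000 nM in this assay, at which 2 of the 3 values shown sit, and compound 3 sits at that limit.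

Compound 4 `OC[C@H]1O[C@@H](n2cnc3c(NCc4ccccc4OC(F)F)ncnc32)[C@H](O)[C@@H]1O` has not yet been measured. It differs from compound 3 as follows: 2-(difluoromethoxy)phenyl in place of 2,3-dihydroxyphenyl on a saturated chain carbon bound to a nitrogen on an aromatic ring.

For the measured compounds named here, only one measured step bears on this change, and that is a step that the two limits leave unreadable from compound 1 to compound 3. It offers neither a size nor a direction, so no step beyond the usual scatter can be forecast in this assay. The most likely result for compound 4 is another limit, because of the limit of > 166000 nM in this assay, at which 2 of the 3 values shown sit. The estimated step of a number no higher from compound 3 to compound 4 (the limit leaves the size open) carries no direction that the data can support. The estimated value for compound 4 is 166000 nM, with an expected range from 50000 nM to 400000 nM.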

Compound 4, half-maximal inhibitory concentration: > 166000 nM
Compound 4: a limit, no number; the forecaster's own chance of this, stated with the estimate: 85%; the middle value lies on the limit itself.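

In this assay compound 4 gives > 166000 nM, which is a limit of the assay and not a number. For the compounds shown here, no step from compound 1 or compound 3 to compound 4 can be read, as all three stand only at a limit: the limit of > 166000 nM in this assay, at which 3 of the 4 values shown sit. The compounds shown leave open whether these aromatic groups differ at all in this assay.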